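Thiophen-2-yl for Phenyl on Two Related Cores

The source may report more compounds than this note shows. Statements on the series, on what has been measured and on what is new or still open speak of the compounds shown alone.

Of the compounds shown here, three have been measured in a functional assay on HL-60 cells (Homo sapiens) for cytotoxicity, read by ELISA, with a stated time of 2 days; on this read-out higher numbers stand for weaker inhibition and lower numbers for stronger inhibition. Compound 1, `Oc1cccc(-c2cc(-c3ccccc3)cc(-c3ccccc3)n2)c1`, gives 11500 nM. Compound 2, `Oc1cccc(-c2cc(-c3ccccc3)cc(-c3cccs3)n2)c1`, differs from it by thiophen-2-yl in place of phenyl on an aromatic carbon, and this change gave a 1.2-fold higher number from compound 1 to compound 2 (0.09 log units; within the scatter). In this assay compound 2 gives 14100 nM. Compound 3, `Oc1cccc(-c2cc(-c3ccccc3)nc(-c3ccccc3)c2)c1`, is built from the same atoms as compound 1 joined differently; the difference between the two cores is not broken down here. In this assay compound 3 gives 13500 nM, and its number and that of compound 2 lie within the usual scatter of each other, as do those of compound 3 and compound 1.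

Compound 4, `Oc1cccc(-c2cc(-c3ccccc3)nc(-c3cccs3)c2)c1`, has not yet been measured. It differs from compound 3 by thiophen-2-yl in place of phenyl on an aromatic carbon, and the surroundings of the place are described in the same words as for the change from compound 1 to compound 2, so it is the same kind of change on the core of compound 3.

The step from compound 3 to compound 4 is expected to be a 1.2-fold higher number from compound 3 to compound 4 (0.07 log units; within the scatter) in this assay, because the same change earlier gave a 1.2-fold higher number from compound 1 to compound 2 (0.09 log units; within the scatter). On that basis compound 4 is estimated at about 16000 nM, with a likely range from 8000 nM to 32000 nM.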

Compound 4, half-maximal inhibitory concentration: 18900 nM
For compound 4 the middle estimate is 1.2-fold (0.07 log units) below the measured one, and the stated range covers the measured number.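

In this assay, thiophen-2-yl in place of phenyl on the core of compound 3 gave a 1.4-fold higher number from compound 3 to compound 4 (0.15 log units; within the scatter), and set beside the earlier step on the core of compound 1, the two results agree: the same change on two cores in this assay, a 1.2-fold higher number (0.09 log units; within the scatter) from compound 1 to compound 2 and a 1.4-fold higher number (0.15 log units; within the scatter) from compound 3 to compound 4, 1.1-fold (0.06 log units) apart, within the scatter of two such steps. This shows that, on these two cores, the change behaved alike and left the number within the scatter each time. Going by these compounds alone, it does not show that a real effect of the change carries from one core to the other, since neither step is large enough to be told from repeated measurement, and the agreement rests on only two pairs in a single assay.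

The compounds shown leave open how the numbers would respond to an amine or a carboxylic acid in place of the hydroxy group of the 3-hydroxyphenyl group. They also leave open whether furan-2-yl or a pyridine ring in place of thiophen-2-yl would give steps that match across the two cores.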